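Aryl swap on the ring amine of an aminothiophene ketone

The compounds below may be only part of what the source reports. "The series", "measured", "known", "first", "only" and "open" are said of these compounds alone.

Measured compounds:
compound 1 `Nc1scc(CN2CCN(c3cccnc3)CC2)c1C(=O)c1ccc(Cl)cc1`, in an assay on CHO cells for displacement of a labelled ligand from adenosine receptor A3 (Homo sapiens), read by scintillation counting, with a stated time of 120 min, tested at 10 uM (on this read-out lower numbers stand for less inhibition and higher numbers for more inhibition at the one concentration tested (going by the name of the read-out)), compound 1 gives 0%
compound 2 `Nc1scc(CN2CCC(c3ccc(Cl)cc3)CC2)c1C(=O)c1ccc(Cl)cc1`, compound 2 gives 6%
compound 3 `Nc1scc(CN2CCN(c3ccc(C(F)(F)F)cc3)CC2)c1C(=O)c1cccc(C(F)(F)F)c1`, compound 3 gives 0%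

On these numbers compound 1 stands level with compound 3 at the digits shown, and together they are the lowest of the three values; compound 2 lies a few points higher, but that gap is within the scatter of this kind of measurement, so the three compounds cannot be told apart.

The account follows the step from compound 1 to compound 4 `Nc1scc(CN2CCN(c3ccc(F)c(Cl)c3)CC2)c1C(=O)c1ccc(Cl)cc1`, which has not yet been measured. The change is 3-chloro-4-fluorophenyl in place of pyridin-3-yl on an amine nitrogen in a ring. Going by the values given here, no step between two measured compounds that differ in only one place is available, so nothing directly bears on this exchange. Compounds 2 and 3, which carry different groups at the same place or on a related ring, show values no further from compound 1 than the scatter allows. The expectation for the step is therefore none beyond the scatter, in either direction.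

Compound 4 is estimated to give 3%, with a range from -6% to 14%, which means an expected step of a number 3 percentage points higher from compound 1 to compound 4 (within the scatter).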

Compound 4, a percentage reported as inhibition, at one concentration (the size of the read-out at that concentration, not a potency): 0%
Compound 4: middle estimate off by 3 percentage points, on the high side; low and high end bracket the measured number.
By their numbers in this assay, from the lowest: compounds 1, 3, 4 and 2 (each within the scatter of the next).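

In this assay, going by these compounds alone, the exchange of pyridin-3-yl for 3-chloro-4-fluorophenyl on an amine nitrogen in a ring gives the first reading of a single change at this place: no change at the digits printed from compound 1 to compound 4 (within the scatter). The step replaces a ring with a nitrogen and a hydrogen-bond acceptor by a carbon-only aromatic ring bearing chlorine and fluorine, and at the one concentration tested the read-out does not separate the two compounds. No measurement here offers an explanation for this result.

Neither compound reads clear of the scatter, so this step cannot show whether anything at this place can raise inhibition in this assay, and a result at this level says little about how much the aryl group matters. The compounds shown leave open whether a benzyl group, a simple alkyl chain or an aryl ring bearing a carboxylic acid on that same nitrogen would give a reading beyond the scatter of compound 1.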